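The source may hold more compounds than are shown below. What is called first, only, known or untested is meant among the compounds shown, and "the series" means these compounds.

Measured so far:
- compound 1 `CC1=C(C(=O)OCC(C)C)C(c2cccs2)NC(=O)N1`: 25%
- compound 2 `CC1=C(C(=O)OCC(C)C)C(c2cccs2)NC(=O)N1C`: 9%
- compound 3 `CC1=C(c2ncc(C)o2)C(c2ccoc2)NC(=O)N1`: 21%

In an assay on membranes from CHO cells for displacement of a labelled ligand from adenosine receptor A1 (Homo sapiens), read by scintillation counting, with a stated time of 60 min, tested at 1 uM (on this read-out higher numbers stand for more inhibition at the one concentration tested (going by the name of the read-out) and lower numbers for less inhibition), compound 1 gives 25%, the highest of the three numbers seen here. Compound 3, with 21%, lies within the usual scatter of compound 1, so the two cannot be told apart on this read-out. Among the measured compounds shown here, compound 2 is the furthest away: the single one-place step that has been measured, a number 16 percentage points lower from compound 1 to compound 2 (beyond the scatter), is beyond the scatter and comes from a methyl in place of hydrogen on an amide-type nitrogen in a ring.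

Compound 4 `CC1=C(C(=O)OC2CCC2)C(c2cccs2)NC(=O)N1` has not yet been measured. It differs from compound 1 by cyclobutyl in place of isobutyl on an oxygen next to a carbonyl group; put another way, isobutoxy becomes cyclobutyloxy. The groups that leave and enter are of the same size and carry no donors, acceptors or charge.

For the measured compounds named here, none of the measured steps bears on this change: the only step on record, from compound 1 to compound 2, concerns a different place in the shared core. With nothing in the data pointing up or down, the expectation for compound 4 is a step within the scatter, no change at the digits printed from compound 1 to compound 4 (within the scatter). The estimate for compound 4 in this assay is therefore 25%, expected to fall between 10% and 40%.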

Compound 4, a percentage reported as inhibition, at one concentration (the size of the read-out at that concentration, not a potency): 24%
Compound 4: middle estimate off by 1 percentage points, on the high side; low and high end bracket the measured number.
By their numbers in this assay, from the lowest: compound 2; then compounds 3, 4 and 1 (each within the scatter of the next).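

In this assay, among the compounds shown here, the first step at the place on an oxygen next to a carbonyl group is a number 1 percentage points lower from compound 1 to compound 4 (within the scatter), so compound 1 and compound 4 cannot be told apart at this one concentration. Isobutyl and cyclobutyl have the same heavy-atom count, but only cyclobutyl contains a ring, and on this read-out that difference in shape of the carbon group leaves no measurable mark. The step at the amide-type nitrogen in a ring, a number 16 percentage points lower from compound 1 to compound 2 (beyond the scatter), lies beyond the scatter, so the two places in the shared core have now given different outcomes for one change each, and nothing available explains either outcome.

Isobutyl and cyclobutyl are both made of carbon alone, so it remains open how this place would respond to a group carrying other atoms, such as an amine or a carboxylic acid, or to a longer chain. A reading at a single concentration also leaves open whether compound 1 and compound 4 would still look alike across a full range of concentrations.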